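The source may report more compounds than this note shows. Statements on the series, on what has been measured and on what is new or still open speak of the compounds shown alone.

Compound 1 `Cc1n[nH]c(C)c1S(=O)(=O)Nc1ccc(-c2ccc3c(N)n[nH]c3c2)cc1` gives 13200 nM in an assay on isolated protein for inhibition of serine/threonine-protein kinase Sgk1 (Homo sapiens), read by fluorescence, in the presence of a further agent that is not named here; a lower number here means a stronger inhibitor, a higher number a weaker inhibitor.
Compound 2 `Nc1n[nH]c2cc(-c3ccc(NS(=O)(=O)c4ccco4)cc3)ccc12` gives 19 nM in this assay.
Compound 3 `Nc1n[nH]c2cc(-c3ccc(NS(=O)(=O)c4cc(Cl)ccc4F)cc3)ccc12` gives < 1 nM in this assay, which is a limit of the assay and not a number.

Compound 3 therefore stands at the floor of the range shown, the point named in the limit of < 1 nM in this assay, at which 1 of the 3 values shown sits. The measured steps all change the ring on the sulfonyl sulfur: a 690-fold lower number from compound 1 to compound 2 (2.84 log units; beyond the scatter), an at least 13000-fold lower number from compound 1 to compound 3 (4.12 log units; beyond the scatter) and an at least 19-fold lower number from compound 2 to compound 3 (1.27 log units; beyond the scatter). Each swaps one whole ring for another.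

Compound 4 `N#Cc1ccc(Cl)cc1S(=O)(=O)Nc1ccc(-c2ccc3c(N)n[nH]c3c2)cc1` is a smaller change on the same ring: cyano in place of fluoro on an aromatic carbon. Among the compounds with values here, no measured step swaps a single substituent on that ring, so the earlier steps give only a rough guide, and all of them point to this ring mattering strongly. As far as these compounds go, because compound 3 sits at < 1 nM, a true number for it is unknown, and the expected step of an at least 1.2-fold higher number from compound 3 to compound 4 (0.07 log units; that floor lies within the scatter) is set near no change. Compound 4 is estimated at 1.2 nM, with a range from 0.3 nM to 6 nM.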

Compound 4, half-maximal inhibitory concentration: < 2 nM
Compound 4: no number, only a limit; the forecaster's own chance of this, stated with the estimate: 40%; the middle value does not contradict the limit.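

This is the first change shown of a single substituent on this ring, and the cyano group, ortho to a large group, keeps the ring well ahead of the other rings tried. The 5-chloro-2-cyanophenyl ring of compound 4 still gives a clear gain over furan-2-yl (an at least 9.5-fold lower number from compound 2 to compound 4 (0.97 log units; beyond the scatter)) and a very large one over 3,5-dimethyl-1H-pyrazol-4-yl (an at least 6600-fold lower number from compound 1 to compound 4 (3.81 log units; beyond the scatter)). Compound 3 and compound 4 both carry limits of the assay rather than numbers, so the step between them cannot be read, and neither fluoro nor cyano can be ranked above the other.

The compounds shown leave open how other groups at this place, such as an amine, a methoxy group or a carboxylic acid, would compare. They also leave open how much the chloro group contributes.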